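Swapping an amino for a hydroxy on a cytotoxicity-tested chalcone

The compounds below may be only part of what the source reports. "The series", "measured", "known", "first", "only" and "open" are said of these compounds alone.

Measured compounds:
- Compound 1 `Nc1cccc(C(=O)/C=C/c2ccc3c(c2)B(O)OC3)c1`: in an ADME assay on L929 cells (Mus musculus) for cytotoxicity, read by resazurin assay, with a stated time of 72 h (on this read-out higher numbers stand for weaker inhibition and lower numbers for stronger inhibition), compound 1 gives 10 ug/mL.
- Compound 2 `CCc1ccc(C(=O)/C=C/c2ccc3c(c2)B(O)OC3)cc1`: in this assay compound 2 gives a value reported only as a limit of the assay, > 10 ug/mL.
- Compound 3 `COc1cc(C(=O)/C=C/c2ccc3c(c2)B(O)OC3)ccc1[N+](=O)[O-]`: in this assay compound 3 gives a value reported only as a limit of the assay, > 10 ug/mL.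

Compound 1 is the only one of the three with a number rather than a limit in this assay. Going by the values given here, the other two values sit at the limit of > 10 ug/mL in this assay, at which 2 of the 3 values shown sit, so no step between measured compounds can be drawn, and nothing in these data shows a difference in cytotoxicity being traced to any single structural change.

Compound 4 `O=C(/C=C/c1ccc2c(c1)B(O)OC2)c1cccc(O)c1` is the not yet measured partner of compound 1. It differs from it in one place: hydroxy in place of amino on an aromatic carbon. The shared core, the propenone linker and the ring bearing the boron are unchanged.

Since no measured step is available to lean on, the change from compound 1 to compound 4 in this assay is expected to be small, none beyond the scatter, and with a slight lean toward weaker inhibition, shown as a 1.2-fold higher number from compound 1 to compound 4 (0.08 log units; within the scatter). Compound 4 is therefore estimated to give about 12 ug/mL in this assay, within a range from 5 ug/mL to 30 ug/mL.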

Compound 4, half-maximal inhibitory concentration: 7.56 ug/mL
Beside the measured number, compound 4's estimate is 1.6-fold (0.20 log units) above it, and the stated range covers the measured number.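

With compound 4 there is now a pair of compounds that differ in only one place, and in this assay the step reads a 1.3-fold lower number from compound 1 to compound 4 (0.12 log units; within the scatter). On this carbon of the aromatic ring, meta to a large group, going from 3-aminophenyl to 3-hydroxyphenyl therefore leaves the read-out within the usual scatter, so this assay does not tell the two groups apart in this pair, which share everything else in their structures. The steps to the remaining two compounds cannot be read, because their values are limits and not numbers: the limit of > 10 ug/mL in this assay, at which 2 of the 4 values shown sit.

This single pair leaves open whether a group of a different kind on the same carbon, such as a carboxylic acid or a nitrile, would also stay within the scatter or would shift the number clearly in either direction. It also leaves open whether amino and hydroxy would remain indistinguishable on another carbon of this ring, or when attached to a different core.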